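Moving the chlorine on the phenyl of compound 1

This account rests on a few compounds, and the source may have more. Where it says the series, first, only, none or still open, it means among the compounds named here.

Measured compounds:
compound 1, `O=C1CSC(c2cccc(Cl)c2)N1CCN1CCCCC1`: 77%
compound 2, `O=C1CSC(c2ccc(O)cc2)N1CCN1CCCCC1`: 87%
compound 3, `O=C1CSC(c2ccccc2[N+](=O)[O-])N1CCN1CCCCC1`: 100%

Of the compounds shown here, three sharing one core have been tested in an ADME assay on Vero cells (Chlorocebus sabaeus) for cytotoxicity, read by neutral red uptake, tested at 197 ug/mL; on this read-out higher numbers stand for a weaker effect at the one concentration tested and lower numbers for a stronger effect. Compound 1 stands at the low end of the three numbers: the step of a number 10 percentage points higher from compound 1 to compound 2 (within the scatter) is within the scatter, so compound 1 and compound 2 cannot be told apart, while compound 3 gives a number that lies beyond the scatter above compound 1.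

The unmeasured compound 4, `O=C1CSC(c2ccccc2Cl)N1CCN1CCCCC1`, differs from compound 1 only in the group on the saturated ring carbon: 2-chlorophenyl in place of 3-chlorophenyl on a saturated ring carbon. Among the compounds with values here, no measured step covers this change. Within the data shown here, the one step that exists, from compound 1 to compound 2, swaps the chlorophenyl for a hydroxyphenyl and stays within the scatter, so it says nothing about shifting the chlorine within the ring. Among the measured compounds shown here, compound 3 carries a different group at the same place and gives 100%, but no step between compound 1 and compound 3 is known. With nothing to point either way, the step of a number 5 percentage points higher from compound 1 to compound 4 (within the scatter) is expected to stay within the scatter. Compound 4 is therefore estimated at 82%, with a range from 65% to 100%.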

Compound 4, a percentage reported as activity, at one concentration (the size of the read-out at that concentration, not a potency): 71%
Beside the measured number, compound 4's estimate is 11 percentage points above it; the range from low to high includes it.
By their numbers in this assay, from the lowest: compounds 4, 1 and 2 (each within the scatter of the next, the first and the last beyond it); then compound 3.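

In this assay, within the data shown here, the step to 2-chlorophenyl in place of 3-chlorophenyl on the saturated ring carbon gives a number 6 percentage points lower from compound 1 to compound 4 (within the scatter), so these two placings of the chlorine cannot be told apart, and this is the first measured step that keeps the atoms of the group and alters only how they are joined. The position does show a modest response to other exchanges, since chloro in place of nitro on an aromatic carbon gives a number 29 percentage points lower from compound 3 to compound 4 (beyond the scatter) and 2-chlorophenyl in place of 4-hydroxyphenyl gives a number 16 percentage points lower from compound 2 to compound 4 (beyond the scatter), although compound 1 remains within the scatter of both compound 2 and compound 4. Nothing available bears on why these numbers differ.

The compounds shown leave open whether a different group on the phenyl, such as an amine, a carboxylic acid or a methoxy group, would shift the read-out further in either direction. They also leave open whether a longer chain in place of the ethylene link on the ring nitrogen would alter these steps.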